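The source may report more compounds than this note shows. Statements on the series, on what has been measured and on what is new or still open speak of the compounds shown alone.

Compound 1 `Cc1ccc(NC(=O)Nc2cccc(CNc3nccnc3Cl)c2)cc1C`: 8930 nM
Compound 2 `Cc1ccc(NC(=O)Nc2cccc(CNc3nccnc3Cl)c2)cc1Cl`: 7390 nM
Compound 3 `Cc1ccc(NC(=O)Nc2cccc(CNc3nccnc3Cl)c2)c(C)c1`: 9230 nM

In a functional assay on T-24 cells (Homo sapiens) for antiproliferative activity, read by MTT assay, with a stated time of 48 h (a lower number here means a stronger inhibitor, a higher number a weaker inhibitor), compound 3 gives 9230 nM, the highest number of the three shown, yet both steps leading to it, a 1.0-fold higher number from compound 1 to compound 3 (0.01 log units; within the scatter) and a 1.2-fold higher number from compound 2 to compound 3 (0.10 log units; within the scatter), lie within the scatter, so the three compounds cannot be told apart on these numbers. Compound 4 `O=C(Nc1cccc(CNc2nccnc2Cl)c1)Nc1ccc(F)c(Cl)c1` differs from compound 3 at the same position: 3-chloro-4-fluorophenyl in place of 2,4-dimethylphenyl on an amide-type nitrogen. Among the compounds with values here, the steps that bear on this are a 1.2-fold higher number from compound 2 to compound 3 (0.10 log units; within the scatter) and a 1.2-fold lower number from compound 1 to compound 2 (0.08 log units; within the scatter), each a swap of substituents on this phenyl ring and each within the scatter. For compound 4 the step of a 1.2-fold lower number from compound 3 to compound 4 (0.06 log units; within the scatter) is therefore expected to stay within the scatter as well. Compound 4 is estimated at 8000 nM, with a range from 4000 nM to 16000 nM.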

Compound 4, half-maximal inhibitory concentration: 4990 nM
The estimate for compound 4 lay 1.6-fold (0.20 log units) above the measured number; low and high end bracket the measured number.
By their numbers in this assay, from the lowest: compounds 4, 2, 1 and 3 (each within the scatter of the next).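

In this assay, within the data shown here, the 3-chloro-4-fluorophenyl group is the first ring here to carry fluoro, and the steps of a 1.8-fold lower number from compound 3 to compound 4 (0.27 log units; within the scatter) and a 1.5-fold lower number from compound 2 to compound 4 (0.17 log units; within the scatter) and a 1.8-fold lower number from compound 1 to compound 4 (0.25 log units; within the scatter) all stay within the scatter. At this position on the amide-type nitrogen, the four rings therefore cannot be told apart, whether they carry methyl, chloro or fluoro groups. No accompanying measurement offers an explanation for this result. From the compounds shown here alone, whether an amine, a carboxylic acid or a longer chain on this phenyl ring would give a step beyond the scatter stays open. So does the effect of any change elsewhere on the shared core.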